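A few compounds are considered here, and "the series" means these few. Any claim that something is new, unique, unknown or untested is made for them only; others in the source may bear on it.

Going by the values given here, in a functional assay on MDA-MB-231 cells (Homo sapiens) for antiproliferative activity, read by MTT assay, with a stated time of 48 h (on this read-out higher numbers stand for weaker inhibition and lower numbers for stronger inhibition), compound 2 `O=C(Nc1cc(Sc2ncn[nH]2)c(O)c2ccccc12)c1ccc(Cl)cc1` gives 25700 nM, the only number among the three measured compounds. Compound 1 `COc1cccc(C(=O)Nc2cc(Sc3ncn[nH]3)c(O)c3ccccc23)c1` reaches only the limit of > 100000 nM in this assay. Compound 3 `O=C(Nc1cc(Sc2ncn[nH]2)c(O)c2ccccc12)c1cccc(Cl)c1` likewise stands at the limit of > 100000 nM. Both of those values sit at the limit of > 100000 nM in this assay, at which 2 of the 3 values shown sit, so the step of an at least 3.8-fold lower number from compound 1 to compound 2 (0.59 log units; beyond the scatter) and the step of an at least 3.8-fold higher number from compound 2 to compound 3 (0.59 log units; beyond the scatter) are known only by their lower bounds, and the step that the two limits leave unreadable from compound 1 to compound 3 cannot be read. Compound 4 `O=C(Nc1cc(Sc2ncnc3nc[nH]c23)c(O)c2ccccc12)c1ccc(Cl)cc1` differs from compound 2 by a group of 9 heavy atoms (5 carbon, 4 nitrogen; one five-membered aromatic ring with 2 hetero atoms, one six-membered aromatic ring with 2 hetero atoms) in place of a group of 5 heavy atoms (2 carbon, 3 nitrogen; one five-membered aromatic ring with 3 hetero atoms), on a sulfur. Among the compounds with values here, all three measured steps alter the group on the carbonyl carbon and leave the group on the sulfur untouched, so none of them bears on this change; no step at the sulfur has been measured. Within the data shown here, the expected step of a 1.0-fold lower number from compound 2 to compound 4 (0.01 log units; within the scatter) therefore rests on no precedent, and no change in either direction beyond the scatter is expected. Compound 4 is estimated at 25000 nM, with a range from 5000 nM to 100000 nM.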

Compound 4, half-maximal inhibitory concentration: 23000 nM
Compound 4: middle estimate off by 1.1-fold (0.04 log units), on the high side; the range from low to high includes it.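

Going by these compounds alone, this is the first step measured at the sulfur. In this assay, the two-ring group of 9 heavy atoms in place of 1H-1,2,4-triazol-5-yl gives a 1.1-fold lower number from compound 2 to compound 4 (0.05 log units; within the scatter), so the two compounds cannot be told apart on this read-out. With the 4-chlorophenyl group on the carbonyl carbon kept the same, this pair shows that the sulfur can carry a second aromatic ring without a readable loss of antiproliferative activity, and nothing shown gives a reason why the two groups read alike.

Both groups on the sulfur are shown only with the 4-chlorophenyl group, so it stays open whether the match holds with the other groups on the carbonyl carbon. Also open, from the compounds shown here alone, is how a plain phenyl ring, an aminoethyl chain or a carboxylic acid on the sulfur would read.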